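Hydroxy on the anilino ring: compound 3 to compound 4

A few compounds are considered here, and "the series" means these few. Any claim that something is new, unique, unknown or untested is made for them only; others in the source may bear on it.

Measured so far in a functional assay on the whole organism (strain albino) for inhibition, with Rattus norvegicus as the target, read by paw edema, with a stated time of 1 h, at a dose of 100 mg/kg by the oral route; a lower number here means less inhibition, a higher number more inhibition at the dose given (going by the name of the read-out):
compound 1 `Cn1c(SCC(=O)Nn2c(COc3ccc(Cl)cc3Cl)nc3ccccc3c2=O)nc(-c2ccccc2)c(C#N)c1=O` gives 54.6%;
compound 2 `Cn1c(SCC(=O)Nn2c(COc3ccc(Cl)cc3Cl)nc3ccccc3c2=O)nc(-c2ccc(O)cc2)c(C#N)c1=O` gives 80%;
compound 3 `N#Cc1c(Nc2ccccc2)nc(SCC(=O)Nn2c(COc3ccc(Cl)cc3Cl)nc3ccccc3c2=O)nc1-c1ccccc1` gives 77.3%.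

Compound 3 sits with compound 2 at the upper end of the three numbers; the gap between compound 3 and compound 2 lies within the scatter, while the gap from compound 1 up to compound 3 lies beyond it. Compound 3 and compound 4 `N#Cc1c(Nc2ccc(O)cc2)nc(SCC(=O)Nn2c(COc3ccc(Cl)cc3Cl)nc3ccccc3c2=O)nc1-c1ccccc1` share the whole core and differ only as follows: hydroxy in place of hydrogen on an aromatic carbon. Among the compounds with values here, the one measured step of the same kind is a number 25.4 percentage points higher from compound 1 to compound 2 (beyond the scatter), a modest rise beyond the scatter, made on the other aromatic ring of the core. Within the data shown here, with only that single step to go by, the same direction is expected here, though compound 3 already starts high, so the rise may come out smaller. For compound 4 the expected step is a number 9.7 percentage points higher from compound 3 to compound 4 (within the scatter). Compound 4 is estimated at 87%, with a range from 73% to 97%.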

Compound 4, a percentage reported as inhibition, in the whole organism at one dose (the size of the read-out at that dose, not a potency): 72.7%
Compound 4: the middle estimate sits 14.3 percentage points above what was measured; measured number outside the range, below it.
By their numbers in this assay, from the lowest: compound 1; then compounds 4, 3 and 2 (each within the scatter of the next).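

In this assay, hydroxy in place of hydrogen on the anilino ring, para to a large group, gives a number 4.6 percentage points lower from compound 3 to compound 4 (within the scatter), so this position shows no measurable response to the change. The same change therefore does not carry a constant effect from one core to the other: the same change on two cores in this assay, a number 25.4 percentage points higher (beyond the scatter) from compound 1 to compound 2 and a number 4.6 percentage points lower (within the scatter) from compound 3 to compound 4, 30 percentage points apart, beyond the scatter of two such steps Any rule that hydroxy raises the number rests on the pair of compound 1 and compound 2 alone, and compound 4 goes against it.

From the compounds shown here alone, whether a different group at this place, such as an amine, a methoxy group or a carboxylic acid, would move the number beyond the scatter remains open. Also open, going by these compounds, is whether compound 3 and compound 4 would separate at other doses or at later times.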